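The compounds below may be only part of what the source reports. "The series", "measured", "known", "first", "only" and "open" are said of these compounds alone.

Compound 1 `CCCc1nc(-c2ccccc2)c(CNCCCN2CCN(c3cccc(OC)c3)CC2)o1`, with 36.4% in an assay on HEK293 cells for inhibition of Voltage-dependent T-type calcium channel subunit alpha-1G (Homo sapiens), read by fluorescence, tested at 10 uM; on this read-out lower numbers stand for less inhibition and higher numbers for more inhibition at the one concentration tested (going by the name of the read-out); compound 2 `CCCc1nc(-c2ccccc2)c(CNCCN2CCN(c3cccc(C)c3C)CC2)o1`, with 66.7% in this assay.

Compound 2 holds the higher of the two numbers, and its gap to compound 1 is beyond the scatter. Compound 3 `CCCc1nc(-c2ccccc2)c(CNCCN2CCN(c3ccc(OC)cc3)CC2)o1` is not yet measured. It differs from compound 2 by 4-methoxyphenyl in place of 2,3-dimethylphenyl on an amine nitrogen in a ring. Without a matched step between measured compounds, the expected change is a moderate decrease in this assay, a number 21.7 percentage points lower from compound 2 to compound 3 (beyond the scatter), since the nearest measured analogue carrying a methoxyphenyl, compound 1, gives 36.4%. Compound 3 is therefore estimated at 45%, in a range from 25% to 65%.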

Compound 3, a percentage reported as inhibition, at one concentration (the size of the read-out at that concentration, not a potency): 51.5%
For compound 3 the middle estimate is 6.5 percentage points below the measured one; the range from low to high includes it.
By their numbers in this assay, from the lowest: compound 1; then compound 3; then compound 2.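

With everything else held constant, the swap of 2,3-dimethylphenyl for 4-methoxyphenyl on an amine nitrogen in a ring gives, in this assay, a number 15.2 percentage points lower from compound 2 to compound 3 (beyond the scatter). This first matched step shows that inhibition at this position responds to the aryl group, while compound 3 still retains a clear part of the read-out. Nothing available explains this step.

The swap changes the kind of substituent and its placement together, and the two effects remain unseparated. Going by these compounds, how an unsubstituted phenyl or a pyridine ring on this nitrogen would read remains open.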